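The source may hold more compounds than are shown below. What is called first, only, known or untested is meant among the compounds shown, and "the series" means these compounds.

Compound 1 `CNC(=O)[C@@H](c1ccccc1)N1CCn2c(CC3CC3)nc(Cl)c2[C@@H]1CCc1ccc(C(F)(F)F)cc1` and compound 2 `C=Cc1nc(CC)n2c1C(CCc1ccc(C(F)(F)F)cc1)N([C@@H](C(=O)NC)c1ccccc1)CC2` share one core and were both tested in a functional assay on CHO cells for antagonist activity at Orexin receptor type 2 (Homo sapiens), read by FLIPR and calcium flux; on this read-out higher numbers stand for weaker inhibition and lower numbers for stronger inhibition. In this assay compound 1 gives 35 nM, and compound 2 gives 23 nM. Compound 1 holds the higher of these two numbers, yet the gap lies within the usual scatter, so no real difference is shown. Compound 3 `CNC(=O)[C@@H](c1ccccc1)N1CCn2c(C)nc(Cl)c2[C@@H]1CCc1ccc(C(F)(F)F)cc1` differs from compound 1 in one place: hydrogen in place of cyclopropyl on a saturated chain carbon bound to an aromatic carbon. Among the measured compounds shown here, no measured pair illustrates a change of this kind, so the expectation rests on the size of the change alone. A modest step toward a higher number is expected, a 1.7-fold higher number from compound 1 to compound 3 (0.23 log units; within the scatter), possibly still inside the scatter. Compound 3 is therefore estimated at 60 nM, ranging from 25 nM to 150 nM.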

Compound 3, half-maximal inhibitory concentration: 13 nM
Compound 3: middle estimate off by 4.6-fold (0.66 log units), on the high side, outside the stated range (below it).
By their numbers in this assay, from the lowest: compounds 3, 2 and 1 (each within the scatter of the next, the first and the last beyond it).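

In this assay the change from cyclopropylmethyl to methyl gives a 2.7-fold lower number from compound 1 to compound 3 (0.43 log units; beyond the scatter) and so moves toward stronger inhibition. At this place on the shared core, then, the cyclopropyl group is not required for activity, and removing it gives a real gain rather than a loss. Nothing available here explains this gain. Still open, from the compounds shown here alone, is how a longer chain such as propyl, or a chain carrying an amine or a carboxylic acid, would behave at this place. A single step also cannot show whether the gain would hold with other groups elsewhere on the core.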